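The source may report more compounds than this note shows. Statements on the series, on what has been measured and on what is new or still open speak of the compounds shown alone.

Measured so far:
Compound 1 `COc1cccc(-c2ccc(COCCCCCN3C[C@H](O)[C@@H](O)[C@H](O)[C@H]3CO)cc2)c1` — in an assay on isolated protein for inhibition of Beta-glucosidase (Homo sapiens) (a higher number here means a weaker inhibitor, a lower number a stronger inhibitor), compound 1 gives 20 nM.
Compound 2 `OC[C@@H]1[C@@H](O)[C@H](O)[C@@H](O)CN1CCCCCOCc1ccc(-c2ccccc2F)cc1` — in this assay compound 2 gives 2 nM.

Among the measured compounds shown here, compound 2 stands lowest of the two numbers; its nearest neighbour is compound 1, and the single measured step, a 10-fold lower number from compound 1 to compound 2 (1.00 log units; beyond the scatter), separates them. Compound 3 `OC[C@@H]1[C@@H](O)[C@H](O)[C@@H](O)CN1CCCCCOCc1ccc(-c2ccc(C(F)(F)F)cc2)cc1` differs from compound 2 in one place: 4-(trifluoromethyl)phenyl in place of 2-fluorophenyl on an aromatic carbon. For the measured compounds named here, the only step that bears on this exchange is that same one, a 10-fold lower number from compound 1 to compound 2 (1.00 log units; beyond the scatter), which shows that changing the group on this aromatic carbon shifts the number modestly and beyond the scatter, but in one direction only, so the second exchange cannot be read from it. Since compound 2 is already the lowest number, a step of a 3.0-fold higher number from compound 2 to compound 3 (0.48 log units; beyond the scatter) is expected, a small rise not far beyond the scatter. Compound 3 is therefore estimated at 6 nM, with a range from 1.5 nM to 25 nM.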

Compound 3, half-maximal inhibitory concentration: 10 nM
The estimate for compound 3 lay 1.7-fold (0.22 log units) below the measured number, within the range that was stated.
By their numbers in this assay, from the lowest: compound 2; then compounds 3 and 1 (each within the scatter of the next).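

In this assay, this second exchange on the aromatic carbon gives a 5.0-fold higher number from compound 2 to compound 3 (0.70 log units; beyond the scatter) and so shows the number at this place moving up as well as down, with compound 2 and its 2-fluorophenyl group keeping the lowest number of the three. Among the compounds shown here, the step of a 2.0-fold lower number from compound 1 to compound 3 (0.30 log units; within the scatter) does not separate 4-(trifluoromethyl)phenyl from 3-methoxyphenyl, which leaves 2-fluorophenyl as the only one of the three groups that stands apart here. Nothing available accounts for the lower number with 2-fluorophenyl.

The compounds shown leave open how 4-fluorophenyl, or a phenyl carrying a carboxylic acid or an amine, would compare on this carbon, so the effect of the group and the effect of where it sits on the ring cannot yet be told apart. They also leave open what a longer chain would do to the number.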